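Replacing 4-aminophenyl with furan-2-yl on a carbonyl carbon

The compounds below may be only part of what the source reports. "The series", "measured", "known", "first", "only" and "open" are said of these compounds alone.

Measured so far in a functional assay on L5178Y cells (Mus musculus) for inhibition, read by MTT assay, with a stated time of 24 h (on this read-out lower numbers stand for stronger inhibition and higher numbers for weaker inhibition), are two compounds:
- compound 1 `COc1ccc([C@@H]2C/C(=N\Nc3ccc(Br)cn3)c3c(O)cc(OC)cc3O2)cc1` at 8000 nM
- compound 2 `COc1ccc([C@@H]2C/C(=N\NC(=O)c3ccc(N)cc3)c3c(O)cc(OC)cc3O2)cc1` at 3900 nM

Compound 2 holds the lower of these two numbers, which makes it the stronger inhibitor of the pair. The next compound is compound 3 `COc1ccc([C@@H]2C/C(=N\NC(=O)c3ccco3)c3c(O)cc(OC)cc3O2)cc1` and the change is furan-2-yl in place of 4-aminophenyl on a carbonyl carbon with furan-2-yl in place of 4-aminophenyl on a carbonyl carbon. For the measured compounds named here, only one measured step bears on this, and it brought in the (4-aminophenyl)carbonyl that now leaves. That step, a 2.1-fold lower number from compound 1 to compound 2 (0.31 log units; beyond the scatter), was modest. Going by the values given here, no measured compound shows the furan-2-yl group, so the expectation in this assay is a small move towards weaker inhibition that stays within the scatter. The estimated change is a 1.3-fold higher number from compound 2 to compound 3 (0.11 log units; within the scatter) and no larger shift is expected. For compound 3 the expected value is 5000 nM with an estimated range from 2000 nM to 12000 nM around it.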

Compound 3, half-maximal inhibitory concentration: 2700 nM
Beside the measured number, compound 3's estimate is 1.9-fold (0.27 log units) above it; the measured number falls inside the stated range.
By their numbers in this assay, from the lowest: compounds 3 and 2 (each within the scatter of the next); then compound 1.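

Furan-2-yl and 4-aminophenyl on this carbonyl carbon cannot be told apart in this assay, with a 1.4-fold lower number from compound 2 to compound 3 (0.16 log units; within the scatter), so in this pair a five-membered ring with 0 hydrogen-bond donors serves as well as a six-membered ring with 1. Measured against the 5-bromopyridin-2-yl compound, the furan-2-yl compound shows a 3.0-fold lower number from compound 1 to compound 3 (0.47 log units; beyond the scatter), so two different aromatic rings on the carbonyl now sit beyond the scatter from compound 1. Nothing available explains why these two rings read alike.

Going by these compounds, it remains open whether a group without a ring, such as a short alkyl chain or a carboxylic acid, would hold this level of inhibition on the same carbonyl carbon. On these data alone, whether the carbonyl itself matters also stays open, since compound 1 differs in both the carbonyl and the ring.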